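Cyclopentyl for methyl on the aryl ketone chain

The source may report more compounds than this note shows. Statements on the series, on what has been measured and on what is new or still open speak of the compounds shown alone.

Compound 2 `CCC(=O)c1ccc(OCCCCOc2cc(C(=O)O)ccc2OC)c(C)c1O` gives 72.6% in an assay on HEK293 cells for positive allosteric modulation of metabotropic glutamate receptor 2 (Rattus norvegicus), read by thallium flux, with a stated time of 2.5 min (on this read-out lower numbers stand for smaller maximal responses and higher numbers for larger maximal responses), the lower of the two numbers measured; compound 1 `Cc1c(OCCCCOc2ccc(C(=O)O)cc2F)ccc(C(=O)CC2CCCC2)c1O` gives 83.8%, and the gap between the two lies outside the scatter. Compound 3 `COc1ccc(C(=O)O)cc1OCCCCOc1ccc(C(=O)CC2CCCC2)c(O)c1C` differs from compound 2 by cyclopentyl in place of methyl on a saturated chain carbon bound to a carbonyl carbon. For the measured compounds named here, no single-change step between measured compounds exists, so the expected step from compound 2 to compound 3 a number 7.4 percentage points higher from compound 2 to compound 3 (within the scatter) is an increase of modest size, only slightly beyond the scatter. Compound 1, which also bears the cyclopentyl, gives 83.8% and supports that direction. Compound 3 is therefore expected at 80%, within 68% to 92%.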

Compound 3, largest response reached (reported as percent of maximum), in percent of the reference or control that the assay uses: 91.8%
The estimate for compound 3 lay 11.8 percentage points below the measured number; the range from low to high includes it.
By their numbers in this assay, from the lowest: compound 2; then compounds 1 and 3 (each within the scatter of the next).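

In this assay, cyclopentyl in place of methyl on a saturated chain carbon bound to a carbonyl carbon now stands as a measured single change, with a number 19.2 percentage points higher from compound 2 to compound 3 (beyond the scatter). With the cyclopentyl held constant, 5-carboxy-2-methoxyphenyl in place of 4-carboxy-2-fluorophenyl gives a number 8 percentage points higher from compound 1 to compound 3 (within the scatter), so these two aryl groups are not told apart. Nothing at hand explains the effect of the cyclopentyl. Still open, going by these compounds, is how cyclobutyl, cyclohexyl or phenyl would compare with cyclopentyl at this position, and whether an amine there would keep the response.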